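Methoxy replaces a long side chain on compound 1

A few compounds are considered here, and "the series" means these few. Any claim that something is new, unique, unknown or untested is made for them only; others in the source may bear on it.

Measured in an ADME assay on L6 cells (Rattus norvegicus) for cytotoxicity (a lower number here means a stronger inhibitor, a higher number a weaker inhibitor), so far:
- compound 1 `OC[C@H]1O[C@@H](n2cnc3c(NC4CCCC4)nc(NCCOCc4ccccc4)nc32)[C@H](O)[C@@H]1O` gives 78800 nM
- compound 2 `COc1nc(NCCC(c2ccccc2)c2ccccc2)c2ncn([C@@H]3O[C@H](CO)[C@@H](O)[C@H]3O)c2n1` gives "not determined" (no result reported)
- compound 3 `OC[C@H]1O[C@@H](n2cnc3c(Nc4ccccc4)nc(NC4CCCC4)nc32)[C@H](O)[C@@H]1O` gives 36300 nM

Compound 1 holds the higher of the two numbers, and compound 3 lies lower by a gap beyond the usual scatter. Compound 2 also carries methoxy but has no result to guide the comparison. Among the compounds with values here, compound 4 `COc1nc(NC2CCCC2)c2ncn([C@@H]3O[C@H](CO)[C@@H](O)[C@H]3O)c2n1` has methoxy in place of (2-(benzyloxy)ethyl)amino on an aromatic carbon and no measured pair differs in one place only. In this assay no step beyond the scatter is expected, and the estimated step of a 1.1-fold higher number from compound 1 to compound 4 (0.06 log units; within the scatter) is small. Compound 4 is estimated at 90000 nM with 35000 nM to 230000 nM as its expected range.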

Compound 4, half-maximal inhibitory concentration: 51600 nM
The estimate for compound 4 lay 1.7-fold (0.24 log units) above the measured number; the measured number falls inside the stated range.
By their numbers in this assay, from the lowest: compounds 3, 4 and 1 (each within the scatter of the next, the first and the last beyond it).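

In this assay, methoxy in place of (2-(benzyloxy)ethyl)amino on this aromatic carbon, between two ring nitrogen atoms, gives a 1.5-fold lower number from compound 1 to compound 4 (0.18 log units; within the scatter) and so leaves the two compounds indistinguishable. In this one pair, the position tolerates the loss of the long chain and its six-membered aromatic ring without a step beyond the scatter. No measurement at hand offers a reason for this. From the compounds shown here alone, whether an amine, a carboxylic acid or a hydroxyl group at this position would behave like methoxy remains open. So does whether the result would hold with a group other than cyclopentylamino on the shared core.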